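Cyclohexylmethyl in Place of a Halogenated Benzyl Group

The source may report more compounds than this note shows. Statements on the series, on what has been measured and on what is new or still open speak of the compounds shown alone.

Compound 1, `CS(=O)(=O)Nc1ccc2c(c1)S(=O)(=O)C=C(c1c(O)c3ccc(Cl)cc3n(Cc3ccc(F)cc3)c1=O)N2`: in an ADME assay on 2209-23 cells (Homo sapiens) for cytotoxicity, read by WST assay (a lower number here means that less compound is tolerated, a higher number that more compound is tolerated), compound 1 shows > 50000 nM, which is a limit of the assay rather than a number.
Compound 2, `CS(=O)(=O)Nc1ccc2c(c1)S(=O)(=O)C=C(c1c(O)c3cc(F)ccc3n(Cc3ccc(F)c(Cl)c3)c1=O)N2`: in this assay compound 2 shows > 50000 nM, which is again only a limit.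

Compound 2 therefore stands exactly where compound 1 stands, at the edge of what this assay can report, which is the limit of > 50000 nM in this assay, at which 2 of the 2 values shown sit. Going by the values given here, no step between the two measured compounds can be read from two limits. Compound 3, `CS(=O)(=O)Nc1ccc2c(c1)S(=O)(=O)C=C(c1c(O)c3cc(F)ccc3n(CC3CCCCC3)c1=O)N2`, differs from compound 2 in a single place: cyclohexyl in place of 3-chloro-4-fluorophenyl on a saturated chain carbon bound to an aromatic nitrogen. The measured compounds give no hint of how that change acts in this assay, so the expected step that the limit leaves unreadable from compound 2 to compound 3 is none beyond the scatter. For compound 3 the estimate is 60000 nM, with a range from 25000 nM to 200000 nM, and this assay is expected most likely to report only a limit once more.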

Compound 3, half-maximal cytotoxic concentration: > 50000 nM
Compound 3 gave a limit, no number; the forecaster's own chance of this, stated with the estimate: 85%; the middle value does not contradict the limit.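

Going by these compounds alone, compound 2 and compound 3 each give only a limit of the assay and no number, so no step between them can be read: the limit of > 50000 nM in this assay, at which 3 of the 3 values shown sit. The compounds shown leave open whether cyclohexylmethyl in place of 3-chloro-4-fluorobenzyl changes the tolerated concentration in this assay at all.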